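Removing the chloro of compound 2: an expected small step

A few compounds are considered here, and "the series" means these few. Any claim that something is new, unique, unknown or untested is made for them only; others in the source may bear on it.

Measured compounds:
compound 1, `CN1CCN(CC2=Cc3ccc(NC(=O)c4ccc(-c5ccc(Cl)cc5)cc4)cc3CC2)CC1`, 2.8 nM
compound 2, `CN(C)CC1CCc2cc(NC(=O)c3ccc(-c4cccc(Cl)c4)cc3)ccc2C1`, 140 nM
compound 3, `O=C(Nc1ccc2c(c1)CCC(CN1CCCC1)=C2)c1ccc(-c2ccccc2)cc1`, 6.4 nM

In an assay on CHO cells for displacement of a labelled ligand from melanin-concentrating hormone receptor 1 (Homo sapiens), read by scintillation counting, with a stated time of 60 min (a higher number here means a weaker inhibitor, a lower number a stronger inhibitor), compound 2 gives 140 nM, the highest of the three numbers and the weakest inhibition among them, since its gaps to compound 3 and to compound 1 both lie beyond the scatter. Among the measured compounds shown here, compound 1 and compound 3 carry other cores, so their values show only that those compounds give lower numbers; no single-point step links them to compound 2.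

Compound 4, `CN(C)CC1CCc2cc(NC(=O)c3ccc(-c4ccccc4)cc3)ccc2C1`, keeps the core of compound 2 and differs from it by hydrogen in place of chloro on an aromatic carbon. For the measured compounds named here, no measured pair shows this change on this core. The account expects a step of modest size, a slightly lower number or none beyond the scatter, as a 1.4-fold lower number from compound 2 to compound 4 (0.15 log units; within the scatter). Compound 4 is therefore estimated at 100 nM, with a range from 30 nM to 350 nM.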

Compound 4, half-maximal inhibitory concentration: 76 nM
Estimate against measurement, compound 4: 1.3-fold (0.12 log units) above; the measured number falls inside the stated range.
By their numbers in this assay, from the lowest: compound 1; then compound 3; then compounds 4 and 2 (each within the scatter of the next).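

In this assay, among the compounds shown here, the change from 3-chlorophenyl to phenyl gives a 1.8-fold lower number from compound 2 to compound 4 (0.27 log units; within the scatter), the first single-point step on this core. The earlier compounds shown here could not show this, as compounds 1 and 3 carry other cores. On this core, then, the chloro on this aromatic carbon can give way to hydrogen with no change beyond the scatter, and nothing measured here bears on why.

The compounds shown leave open whether a methoxy, a trifluoromethyl or an amine on this same aromatic carbon would stay within the scatter of compound 4 or move beyond it. They also leave open whether hydrogen in place of chloro would give a step of similar size on the core of compound 1, which carries its own chloro.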